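Swapping the Dichlorophenyl Pattern on Two Related Cores

The source may report more compounds than this note shows. Statements on the series, on what has been measured and on what is new or still open speak of the compounds shown alone.

Compound 1 `COc1cccc(/C=C2\CCC/C(=C\c3ccc(Cl)cc3Cl)C2=O)c1OC` was examined in a functional assay on HT-1080 cells (Homo sapiens) for cytotoxicity, read by MTT assay, with a stated time of 72 h; a lower number here means a stronger inhibitor, a higher number a weaker inhibitor. For compound 1 the outcome is a limit of the assay rather than a number, namely > 20000 nM, which is the limit of > 20000 nM in this assay, at which 1 of the 3 values shown sits. Compound 2 `COc1cccc(/C=C2\CCC/C(=C\c3ccc(Cl)c(Cl)c3)C2=O)c1OC` gives 10800 nM in this assay. The change between them is 3,4-dichlorophenyl in place of 2,4-dichlorophenyl on a double-bonded chain carbon bound to a double-bonded ring carbon, and it produced an at least 1.8-fold lower number from compound 1 to compound 2 (0.26 log units; that floor lies within the scatter). Compound 3 `COc1ccc(/C=C2\CCC/C(=C\c3ccc(Cl)cc3Cl)C2=O)cc1OC` gives 10500 nM in this assay, a value within the scatter of compound 2. How the core of compound 3 differs from that of compound 1 is not broken down here.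

Compound 4 `COc1ccc(/C=C2\CCC/C(=C\c3ccc(Cl)c(Cl)c3)C2=O)cc1OC` has not yet been measured. It relates to compound 3 by the same change, (3,4-dichlorophenyl in place of 2,4-dichlorophenyl on a double-bonded chain carbon bound to a double-bonded ring carbon). The step is expected to be a 1.3-fold lower number from compound 3 to compound 4 (0.12 log units; within the scatter), resting on an at least 1.8-fold lower number from compound 1 to compound 2 (0.26 log units; that floor lies within the scatter), whose floor lies within the scatter. Compound 4 is therefore estimated at 8000 nM, expected to fall between 3000 nM and 22000 nM.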

Compound 4, half-maximal inhibitory concentration: 3100 nM
Beside the measured number, compound 4's estimate is 2.6-fold (0.41 log units) above it; the measured number falls inside the stated range.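

In this assay, 3,4-dichlorophenyl in place of 2,4-dichlorophenyl gives a 3.4-fold lower number from compound 3 to compound 4 (0.53 log units; beyond the scatter), so on the core of compound 3 the change has an effect that stands clear of the scatter. Whether the size of that step carries over from one core to the other is not shown: the same change on two cores in this assay, an at least 1.8-fold lower number (0.26 log units; that floor lies within the scatter) from compound 1 to compound 2 and a 3.4-fold lower number (0.53 log units; beyond the scatter) from compound 3 to compound 4; the limit leaves it open whether they differ. The result for compound 1 is a limit and not a number: the limit of > 20000 nM in this assay, at which 1 of the 4 values shown sits.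

The compounds shown leave open whether the step would hold on a core bearing an amine or a carboxylic acid. They also leave open how a phenyl ring with a single chlorine or with two fluorines would compare with the two dichlorophenyl groups.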